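Aryl ether to benzyl ether on a cyclohexyl urea

The source may report more compounds than this note shows. Statements on the series, on what has been measured and on what is new or still open speak of the compounds shown alone.

Measured compounds in a functional assay on CRL2813 cells (Homo sapiens) for cytotoxicity, read by sulforhodamine B assay, with a stated time of 5 days; on this read-out higher numbers stand for weaker inhibition and lower numbers for stronger inhibition:
Compound 1 `O=C(Nc1cccc(C(F)(F)F)c1)N[C@H]1CC[C@@H](Oc2ccc(F)cc2)CC1`: compound 1 gives 2600 nM
Compound 2 `COc1ccccc1NC(=O)N[C@H]1CC[C@H](Oc2ccc(F)cc2)CC1`: compound 2 reaches only the assay limit of > 20000 nM
Compound 3 `O=C(Nc1cccc(C(F)(F)F)c1)N[C@H]1CC[C@H](Oc2ccccc2C(F)(F)F)CC1`: compound 3 gives 1400 nM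

Compound 3 holds the lowest of the two numbers shown, but the value of compound 1 lies within the usual scatter of it, so no order between the two can be claimed. Compound 2 is recorded only as a limit, not as a number (the limit of > 20000 nM in this assay, at which 1 of the 3 values shown sits).

Compound 4 `O=C(Nc1cccc(C(F)(F)F)c1)N[C@H]1CC[C@H](OCc2ccc(F)cc2)CC1` differs from compound 3 in one place: 4-fluorobenzyl in place of 2-(trifluoromethyl)phenyl on an oxygen on a saturated carbon. No step between two measured compounds describes this change, so nothing in the numbers shown sets its size or direction. The expectation is a small shift, not beyond the scatter, from compound 3 to compound 4 a 1.8-fold higher number from compound 3 to compound 4 (0.25 log units; within the scatter). Compound 4 is therefore estimated in this assay at 2500 nM, with a range from 900 nM to 9000 nM.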

Compound 4, half-maximal inhibitory concentration: 2650 nM
Beside the measured number, compound 4's estimate is 1.1-fold (0.03 log units) below it; the range from low to high includes it.
By their numbers in this assay, from the lowest: compounds 3, 1 and 4 (each within the scatter of the next). At a limit, above all of these: compound 2.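

On an oxygen on a saturated carbon, putting 4-fluorobenzyl in place of 2-(trifluoromethyl)phenyl gives, in this assay, a 1.9-fold higher number from compound 3 to compound 4 (0.28 log units; within the scatter). Going by these compounds alone, this is the first measured step at this position, and it shows that the benzyl ether and the aryl ether cannot be put in order here, even though the change alters both the group on the ring and how the ring is joined to the oxygen. Nothing shown gives a reason for this step.

The compounds shown leave open how each of those two parts would read alone, which a plain benzyl or a 2-(trifluoromethyl)benzyl group on the same oxygen could separate. They also leave open whether a longer chain such as phenethyl, a pyridine ring or a carboxylic acid at this position would move the number beyond the scatter.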